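Swapping the Thioether Arm in a Weak Series

This account rests on a few compounds, and the source may have more. Where it says the series, first, only, none or still open, it means among the compounds named here.

Two compounds in this set share a core and both fail to show measurable inhibition. Compound 1 `C[C@@H]1CCN(c2cc(-c3ccccc3)nc3ncnn23)C[C@@H]1N(C)c1ncnc2[nH]ccc12` gives > 100000 nM in a functional assay on BGC-823 cells (Homo sapiens) for inhibition, read by MTT assay, with a stated time of 72 h (a lower number here means a stronger inhibitor, a higher number a weaker inhibitor), a value that is a limit of the assay rather than a measured number. Compound 2 `Cc1cc(N2CC[C@@H](C)[C@@H](N(C)c3ncnc4[nH]ccc34)C2)n2nc(SCc3csc4ccc(Cl)cc34)nc2n1` likewise gives > 100000 nM in this assay, again only a limit. Compound 2 thus has no measured position to speak of: the limit of > 100000 nM in this assay, at which 2 of the 2 values shown sit, so no ordering of the two is possible.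

Compound 3 `Cc1cc(N2CC[C@@H](C)[C@@H](N(C)c3ncnc4[nH]ccc34)C2)n2nc(SCc3ccc([N+](=O)[O-])cc3)nc2n1` differs from compound 2 in one place: 4-nitrophenyl in place of 5-chloro-1-benzothiophen-3-yl on a saturated chain carbon bound to a sulfur. Among the compounds with values here, with no measured step to lean on, the expected step in this assay is estimated as a number no higher from compound 2 to compound 3 (the limit leaves the size open), nothing beyond the scatter. Compound 3 is therefore expected to give about 100000 nM in this assay, with a plausible range from 30000 nM to 300000 nM, and most likely the assay will once more report only a limit.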

Compound 3, half-maximal inhibitory concentration: 59600 nM
Estimate against measurement, compound 3: 1.7-fold (0.22 log units) above; measured number inside the range.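

Within the data shown here, compound 3 is the first compound here to give a real number rather than a limit, so the arm on the sulfur is a place where a change can be read at all. Replacing the (5-chloro-1-benzothiophen-3-yl)methyl arm with 4-nitrobenzyl gives an at least 1.6-fold lower number from compound 2 to compound 3 (0.22 log units; that floor lies within the scatter) in this assay. That figure is only a floor, and the true size of the step stays unknown because compound 2 has a limit rather than a number: the limit of > 100000 nM in this assay, at which 2 of the 3 values shown sit.

A single swap cannot separate the part played by the nitro group from the part played by losing the five-membered ring and the chlorine. The compounds shown also leave open how a plain benzyl, a 4-aminobenzyl or a 4-methoxybenzyl arm would read on the sulfur.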